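A Methyl on the Ring Nitrogen of Compound 2

The compounds below may be only part of what the source reports. "The series", "measured", "known", "first", "only" and "open" are said of these compounds alone.

In a functional assay on Raji cells (Homo sapiens) for antiproliferative activity, read by MTT assay, with a stated time of 48 h (on this read-out higher numbers stand for weaker inhibition and lower numbers for stronger inhibition), compound 1 `CN1CCN(CCn2c(N)c(-c3nc4ccccc4[nH]3)c3nc(C#N)c(C#N)nc32)CC1` gives > 50000 nM, which is a limit of the assay and not a number. For the measured compounds named here, compound 2 `CCN(CC)CCCCn1c(N)c(-c2nc3ccccc3[nH]2)c2nc(C#N)c(C#N)nc21` gives 2640 nM, so it holds the only true number in this small set. Between these two compounds, the record shows an at least 18-fold lower number from compound 1 to compound 2 (1.27 log units; beyond the scatter). That single measured step is large, but it lies on the chain and not on the ring where the next change is made.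

Compound 3 `CCN(CC)CCCCn1c(N)c(-c2nc3ccccc3n2C)c2nc(C#N)c(C#N)nc21` keeps the chain of compound 2 and differs from it as follows: methyl in place of hydrogen on an aromatic nitrogen. In short, this is methyl in place of hydrogen on an aromatic nitrogen.

Going by the values given here, no step has yet been measured at this nitrogen, so the change on the chain, an at least 18-fold lower number from compound 1 to compound 2 (1.27 log units; beyond the scatter), sets no size for this one. Among the compounds with values here, it shows only that one structural change can move the numbers in this assay widely, which argues for a broad range. A small move towards weaker inhibition is expected, and the estimated step is a 1.5-fold higher number from compound 2 to compound 3 (0.18 log units; within the scatter). For compound 3, the expected value is 4000 nM, with an estimated range of 1200 nM to 20000 nM.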

Compound 3, half-maximal inhibitory concentration: 920 nM
Compound 3: the middle estimate sits 4.3-fold (0.64 log units) above what was measured; the whole stated range lies above it.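

Methyl in place of hydrogen on this aromatic nitrogen, the change from 1H-benzimidazol-2-yl to 1-methyl-1H-benzimidazol-2-yl, gives a 2.9-fold lower number from compound 2 to compound 3 (0.46 log units; beyond the scatter) in this assay. For the compounds shown here, this is the first evidence about this position, and it shows that the ring nitrogen need not carry its hydrogen for compound 3 to act on these cells: with a single carbon added, inhibition grows stronger, by a modest step that lies beyond the usual scatter. Compound 1 stands at a limit of the assay and not at a number, so the earlier step on the chain gives only a bound, whereas this step is the first here with a true number at both ends: the limit of > 50000 nM in this assay, at which 1 of the 3 values shown sits.

One pair cannot show whether a larger group on the same nitrogen, such as ethyl or benzyl, would carry this gain further or lose it. It also leaves open whether the same methyl would act in the same way on a different chain, such as a shorter or longer one ending in an amine, and the compounds shown give no reason for the change in the number.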